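The source may hold more compounds than are shown below. What is called first, only, known or untested is meant among the compounds shown, and "the series" means these compounds.

In a functional assay on HT-29 cells (Homo sapiens) for antiproliferative activity, read by MTT assay, with a stated time of 48 h (on this read-out higher numbers stand for weaker inhibition and lower numbers for stronger inhibition), compound 1 `O=C(/C=C\Nc1ccc(C(F)(F)F)cc1)c1cn(-c2ccccc2)nc1-c1ccccc1` gives > 50000 nM, which is a limit of the assay and not a number. For the measured compounds named here, compound 2 `O=C(/C=C\Nc1ccc(O)cc1)c1cn(-c2ccccc2)nc1-c1ccccc1` gives 5000 nM, the only true number available. Going by the values given here, the single measured step is an at least 10-fold lower number from compound 1 to compound 2 (1.00 log units; beyond the scatter), and it comes with hydroxy in place of trifluoromethyl on an aromatic carbon. Compound 3 `O=C(/C=C\Nc1ccc(O)cc1)c1cn(-c2ccccc2)nc1-c1ccc(F)cc1` keeps that hydroxy group and differs from compound 2 by fluoro in place of hydrogen on an aromatic carbon, which is fluoro in place of hydrogen on an aromatic carbon, turning phenyl to 4-fluorophenyl. The measured step concerns a different substituent, so it shows that one replacement can matter in this assay but does not directly size this one. The estimated step is a 1.3-fold lower number from compound 2 to compound 3 (0.10 log units; within the scatter), so no change beyond the scatter is expected. Compound 3 is expected to give 4000 nM, with an estimated range of 1300 nM to 15000 nM.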

Compound 3, half-maximal inhibitory concentration: 1900 nM
Estimate against measurement, compound 3: 2.1-fold (0.32 log units) above; measured number inside the range.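

In this assay, for the compounds shown here, the change from phenyl to 4-fluorophenyl comes with a 2.6-fold lower number from compound 2 to compound 3 (0.42 log units; beyond the scatter), so this ring, untouched in the earlier compounds, also responds to a single replacement. Going by these compounds alone, the step is modest, but it is the first to run between two true numbers, and so the first whose size can be read exactly. Nothing given here accounts for why fluoro in place of hydrogen at this carbon lowers the number.

The compounds shown leave open how chloro, methoxy or an amine would read at this same place, and whether fluoro at another carbon of this ring would read alike. They also leave open whether the fluoro step carries over when a carboxylic acid or an amine stands in place of the hydroxy group.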